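The source may report more compounds than this note shows. Statements on the series, on what has been measured and on what is new or still open speak of the compounds shown alone.

In a physicochemical assay for acid dissociation, read by spectrophotometry, at pH 2, compound 1 `COc1ccc(Nc2nc(Cl)cn([C@H](C)C3CC3)c2=O)c(C)n1` gives 3.2 and compound 2 `COc1nc(C)c(Nc2nc(Cl)cn([C@H](C)C3CC3)c2=O)cc1C` gives 3.6, the higher of the two numbers. Compound 3 `Cc1cc(Nc2nc(Cl)cn([C@H](C)C3CC3)c2=O)c(C)nc1OC(F)F` differs from compound 2 by methoxy to difluoromethoxy (difluoromethyl in place of methyl on an oxygen on an aromatic ring), that is, difluoromethyl in place of methyl on an oxygen on an aromatic ring. For the measured compounds named here, the only measured step, a number 0.40 log units higher from compound 1 to compound 2 (beyond the scatter), comes from methyl in place of hydrogen on an aromatic carbon, so it serves only as a gauge of size. Going by the values given here, no measured pair covers a change on this oxygen. A larger move to a lower number is expected, with an estimated a number 1.20 log units lower from compound 2 to compound 3 (beyond the scatter). For compound 3 the estimate in this assay is 2.4, with an expected range of 1.7 to 3.1.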

Compound 3, acid dissociation constant: < 2
Compound 3 ended at the assay's limit; the forecaster's own chance of this, stated with the estimate: 15%; middle value at least 0.40 log units from the limit.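

In this assay, for the compounds shown here, the change on this oxygen reads as a number at least 1.60 log units lower from compound 2 to compound 3 (beyond the scatter) and is the first measured step at this place, running to a lower number where the only earlier step, methyl in place of hydrogen on an aromatic carbon, ran to a higher one. Compound 3 gives < 2 and this is a limit of the assay, not a number. The step is thus a bound and its full size stays unread: the limit of < 2 in this assay, at which 1 of the 3 values shown sits.

Open, as far as these compounds go, is where the number for compound 3 actually lies. Also open, from the compounds shown here alone, is how trifluoromethyl, monofluoromethyl or a longer chain on this oxygen would read.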